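This account rests on a few compounds, and the source may have more. Where it says the series, first, only, none or still open, it means among the compounds named here.

In an assay on Jurkat cells for inhibition of nuclear factor NF-kappa-B p105 subunit (Homo sapiens) (on this read-out lower numbers stand for stronger inhibition and higher numbers for weaker inhibition), compound 1 `O=C(Nc1cc(Cl)cc(Cl)c1)c1cnc(Cl)nc1C(F)(F)F` gives 500 nM. Compound 2 `CN(C(=O)c1cnc(Cl)nc1C(F)(F)F)c1cc(Cl)cc(Cl)c1` differs from compound 1 only by a methyl in place of the amide hydrogen, and in this assay compound 2 gives 2300 nM. Among the compounds with values here, the step of a 4.6-fold higher number from compound 1 to compound 2 (0.66 log units; beyond the scatter) is the only measured step in this set, and it points toward weaker inhibition when that amide hydrogen is replaced. Compound 3 `CCCCNC(=O)c1cc(NC(=O)c2cnc(Cl)nc2C(F)(F)F)cc(C(F)(F)F)c1` carries a butylcarbamoyl group on the shared core. In this assay compound 3 gives only a limit, > 10000 nM, sitting at the limit of > 10000 nM in this assay, at which 1 of the 3 values shown sits. Compound 3 therefore stands at the weak end of the numbers shown, with no exact value known for it.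

Compound 4 `O=C(OC1CCCCC1)c1cc(NC(=O)c2cnc(Cl)nc2C(F)(F)F)cc(C(F)(F)F)c1` is compound 3 with cyclohexyloxy in place of butylamino on a carbonyl carbon. Within the data shown here, no measured step bears directly on this exchange; the one measured step, a 4.6-fold higher number from compound 1 to compound 2 (0.66 log units; beyond the scatter), concerns a different part of the molecule and gives no firm guide. Since compound 3 already sits at the limit, compound 4 is expected to remain weak, with an expected step that the limit leaves unreadable from compound 3 to compound 4 that would not be resolved by the assay. Compound 4 is estimated at 20000 nM, within a range from 5000 nM to 80000 nM, and most likely the assay would again report only a limit.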

Compound 4, half-maximal inhibitory concentration: 1800 nM
The estimate for compound 4 lay 11-fold (1.05 log units) above the measured number; the measured number lies below the stated range.
By their numbers in this assay, from the lowest: compound 1; then compounds 4 and 2 (each within the scatter of the next). At a limit, above all of these: compound 3.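

In this assay, putting cyclohexyloxy in place of butylamino on a carbonyl carbon whose other neighbour is an aromatic carbon gives an at least 5.5-fold lower number from compound 3 to compound 4 (0.74 log units; beyond the scatter). Within the data shown here, the only earlier step concerned the amide hydrogen, so this is the first measured sign that the group on this carbonyl carbon also matters for inhibition, and that a compound with this substituted core can give a readable number. The true size of the step stays unknown because compound 3 has only a limit: the limit of > 10000 nM in this assay, at which 1 of the 4 values shown sits.

The exchange alters several things at once, since oxygen replaces nitrogen, the hydrogen-bond donor of butylamino is lost, and a six-membered ring replaces an open chain, so the compounds shown do not tell which of these changes counts. Butoxy or cyclohexylamino on the same carbonyl carbon would separate the ring from the oxygen, and how a carboxylic acid would behave at this place also remains open.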